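Adding methoxy to compound 3: working notes

This account rests on a few compounds, and the source may have more. Where it says the series, first, only, none or still open, it means among the compounds named here.

Compounds tested so far in a functional assay on RAW264.7 cells (Mus musculus) for inhibition, with stated times of 1 h and 24 h (a higher number here means a weaker inhibitor, a lower number a stronger inhibitor), are these:
- compound 1 `COc1ccccc1C(=O)Nc1cccc(-c2cc(=O)c3c(O)c(OC)c(OC)cc3o2)c1` result 310 nM
- compound 2 `COc1ccc(C(=O)Nc2cccc(-c3cc(=O)c4c(O)c(OC)c(OC)cc4o3)c2)cc1` result "not determined" (no result reported)
- compound 3 `COc1cc2oc(-c3cccc(C(=O)Nc4ccccc4)c3)cc(=O)c2c(O)c1OC` result "not determined" (no result reported)

Compound 3 has no single number in this assay and compound 2 is the one further entry of that kind. Within the data shown here, the only number comes from compound 1 at 310 nM and nothing places compound 3 relative to it.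

Compound 4 `COc1ccccc1NC(=O)c1cccc(-c2cc(=O)c3c(O)c(OC)c(OC)cc3o2)c1` has yet to be measured. The structural change is methoxy in place of hydrogen on an aromatic carbon with methoxy in place of hydrogen on an aromatic carbon, ortho to a large group, so that phenylcarbamoyl becomes (2-methoxyphenyl)carbamoyl.

Among the measured compounds shown here, without a number for compound 3, no measured step exists to size this change. For the measured compounds named here, the expectation therefore rests on a single reference, compound 1 at 310 nM as the sole value available. Against that reference, no step beyond the scatter is expected in this assay and no direction can be favoured, so the range is kept wide. In this assay the value for compound 4 is estimated at 400 nM with an expected range of 120 nM to 1500 nM for the measurement.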

Compound 4, half-maximal inhibitory concentration: 2380 nM
Beside the measured number, compound 4's estimate is 6.0-fold (0.77 log units) below it; measured number above the stated range.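

In this assay, among these compounds, the reversed amide gives a 7.7-fold higher number from compound 1 to compound 4 (0.89 log units; beyond the scatter), the first measured step, and it shows that the direction of the amide matters here even with the 2-methoxyphenyl group and the shared core kept: (2-methoxyphenyl)carbamoyl on the aromatic carbon gives a weaker inhibitor than ((2-methoxyphenyl)carbonyl)amino. The step from compound 3 to compound 4 cannot be read with no number for compound 3, so the contribution of methoxy in place of hydrogen at this position remains unsized, and the result says only that the amide direction carries weight in the presence of that methoxy. Nothing measured here bears on what lies behind the difference between the two amide directions.

Open, from the compounds shown here alone, is whether the amide direction has the same weight without the methoxy group, which would need numbers for compound 3 and a matching unsubstituted partner, and compound 2 gives no reading on moving the methoxy group on the other amide. Also open, going by these compounds, is how a different group on this aromatic carbon, such as fluorine, a hydroxyl or an amine, would read against compound 4.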